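The compounds below may be only part of what the source reports. "The series", "measured", "known", "first", "only" and "open" are said of these compounds alone.

Results so far in a physicochemical assay for permeability, using PAMPA (on this read-out lower numbers stand for lower permeability and higher numbers for higher permeability), are these:
- compound 1 `C[C@@H](Oc1cc2oc(=O)n(CCC(=O)O)c2cc1Cl)c1ccc(F)cn1` reads 31 nm/s
- compound 2 `O=C(O)CCn1c(=O)oc2cc(OCC3CCC3)c(Cl)cc21` reads 12 nm/s

Of these two numbers, compound 1 holds the higher one, and compound 2 sits lower by more than the usual scatter of repeated measurements.

Compound 3 `Cc1cccc([C@@H](C)Oc2cc3oc(=O)n(CCC(=O)O)c3cc2Cl)n1` has not yet been measured. It differs from compound 1 in one place: 6-methylpyridin-2-yl in place of 5-fluoropyridin-2-yl on a saturated chain carbon bound to an oxygen on an aromatic ring and a saturated chain carbon is the counted difference, with 6-methylpyridin-2-yl in place of 5-fluoropyridin-2-yl on a saturated chain carbon bound to an oxygen on an aromatic ring and a saturated chain carbon.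

For the measured compounds named here, no pair of measured compounds shows this swap on its own, so the data give no direct guide to its size. In this assay no step beyond the scatter is expected, and neither direction is favoured. Compound 1 at 31 nm/s is the closest reference point, so the estimate stays near it. The estimated change is small, with a 1.1-fold higher number from compound 1 to compound 3 (0.03 log units; within the scatter) as the expected step. For compound 3 the expected reading is 33 nm/s within an estimated range of 14 nm/s to 75 nm/s on repeat measurements.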

Compound 3, apparent permeability: 21 nm/s
For compound 3 the middle estimate is 1.6-fold (0.20 log units) above the measured one; measured number inside the range.
By their numbers in this assay, from the lowest: compounds 2, 3 and 1 (each within the scatter of the next, the first and the last beyond it).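

In this assay, the only swap shown at this position, 6-methylpyridin-2-yl in place of 5-fluoropyridin-2-yl on a saturated chain carbon bound to an oxygen on an aromatic ring and a saturated chain carbon, gives a 1.5-fold lower number from compound 1 to compound 3 (0.17 log units; within the scatter). The two groups match in heavy atoms, hydrogen-bond donors, hydrogen-bond acceptors and net charge, and this read-out does not separate compound 1 from compound 3, so this particular exchange of one pyridine group for the other leaves no measurable mark here. No measurement shown offers an explanation for this outcome.

A single pair cannot show whether this position generally tolerates change, since both groups are six-membered aromatic rings with one hetero atom and they differ only in what the ring carries. Still open, going by these compounds, is whether a group of a different kind in the same place, such as a pyridine ring bearing a nitrile or a dimethylamino group, or a saturated morpholine ring, would produce a step beyond the scatter in this assay.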